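A few compounds are considered here, and "the series" means these few. Any claim that something is new, unique, unknown or untested is made for them only; others in the source may bear on it.

Measured compounds in a functional assay on HT-29 cells (Homo sapiens) for cytotoxicity, read by MTT assay, with a stated time of 72 h; on this read-out lower numbers stand for stronger inhibition and higher numbers for weaker inhibition:
compound 1 `COc1cc2c(Oc3ccc(NC(=O)c4cc(-c5ccccc5)nc5ccccc45)cc3F)ccnc2cc1OCCCN1CCCCC1` gives 530 nM
compound 2 `COc1cccc(-c2cc(C(=O)Nc3ccc(Oc4ccnc5cc(OCCCN6CCCCC6)c(OC)cc45)c(F)c3)c3ccccc3n2)c1` gives 1740 nM
compound 3 `COc1cc2c(Oc3ccc(NC(=O)c4cc(-c5ccccc5)nc5ccccc45)cc3F)ccnc2cc1OCCCN1CCC(C)CC1` gives 120 nM

Compound 3 stands lowest of the three, and its steps to both others lie beyond the scatter. The change from compound 1 to compound 3 is methyl in place of hydrogen on a saturated ring carbon, a step of a 4.4-fold lower number from compound 1 to compound 3 (0.65 log units; beyond the scatter). The change from compound 1 to compound 2 is methoxy in place of hydrogen on an aromatic carbon, a step of a 3.3-fold higher number from compound 1 to compound 2 (0.52 log units; beyond the scatter).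

Compound 4 `COc1ccc(-c2cc(C(=O)Nc3ccc(Oc4ccnc5cc(OCCCN6CCC(C)CC6)c(OC)cc45)c(F)c3)c3ccccc3n2)cc1` is not yet measured. It differs from compound 3 by methoxy in place of hydrogen on an aromatic carbon. This is the same kind of change as that from compound 1 to compound 2, but the place differs: there the methoxy sits meta to a large group, here para to a large group. The cores of compound 3 and compound 4 share the methyl in place of hydrogen on a saturated ring carbon already covered by methyl in place of hydrogen on a saturated ring carbon.

A step of a 2.5-fold higher number from compound 3 to compound 4 (0.40 log units; beyond the scatter) is expected, resting on the earlier step of a 3.3-fold higher number from compound 1 to compound 2 (0.52 log units; beyond the scatter). The place is not the same, and the expectation is tempered accordingly. Compound 4 is therefore estimated at 300 nM, between 110 nM and 900 nM.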

Compound 4, half-maximal inhibitory concentration: 1110 nM
Estimate against measurement, compound 4: 3.7-fold (0.57 log units) below; measured number above the stated range.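

In this assay methoxy in place of hydrogen on an aromatic carbon raises the number on both cores, here with a 9.3-fold higher number from compound 3 to compound 4 (0.97 log units; beyond the scatter), so the direction carries over from one core to the other but the size does not: the same change on two cores in this assay, a 3.3-fold higher number (0.52 log units; beyond the scatter) from compound 1 to compound 2 and a 9.3-fold higher number (0.97 log units; beyond the scatter) from compound 3 to compound 4, 2.8-fold (0.45 log units) apart, beyond the scatter of two such steps

The two pairs differ in place as well as in core, with the methoxy para to a large group in compound 4 and elsewhere on the ring in compound 2. The gap therefore cannot be assigned to the core alone or to the place alone, and two pairs give no rule for further cores.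

Open, going by these compounds, is the methoxy at its compound 2 place on the core of compound 3, which would separate core from place. Also open, on these data alone, is whether a fluorine or a hydroxyl group at the place it holds in compound 4 gives a step of similar size.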